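This account rests on a few compounds, and the source may have more. Where it says the series, first, only, none or still open, it means among the compounds named here.

Compound 1 `O=c1nc(-c2ccccc2)c2cc(-c3ccc(F)cc3)ccc2[nH]1`: 50000 nM
Compound 2 `CNC(=O)c1cccc(-c2ccc3[nH]c(=O)nc(-c4ccccc4)c3c2)c1`: > 50000 nM (a limit)
Compound 3 `O=c1nc(-c2ccccc2)c2ccc(-c3cccnc3)cc2[nH]1`: 7730 nM

In an ADME assay on L6 cells (Rattus norvegicus) for cytotoxicity, read by fluorescence and resazurin assay, with a stated time of 72 h (a lower number here means that less compound is needed, a higher number that more compound is needed for the effect), compound 1 gives 50000 nM, the higher of the two true numbers. Compound 3 stands lower at 7730 nM, a gap beyond the scatter. Compound 2 reports > 50000 nM, which is a limit of the assay and not a number.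

Compound 4 `CN1CCN(c2ccc3[nH]c(=O)nc(-c4ccccc4)c3c2)CC1` has 4-methylpiperazin-1-yl in place of 4-fluorophenyl on an aromatic carbon. For the measured compounds named here, no measured pair isolates such a change, so the expectation in this assay is only a moderate drop, just beyond the scatter. It leans on compound 3 at 7730 nM, although compound 2 gives no such sign. The estimated step is a 3.3-fold lower number from compound 1 to compound 4 (0.52 log units; beyond the scatter). For compound 4 the expected value is 15000 nM, with an estimated range of 4000 nM to 50000 nM.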

Compound 4, half-maximal effective concentration: > 50000 nM
Compound 4 gave a limit, no number; the forecaster's own chance of this, stated with the estimate: 20%; middle value at least 3.3-fold (0.52 log units) away from the limit.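

In this assay, putting 4-methylpiperazin-1-yl in place of 4-fluorophenyl on this aromatic carbon gives a number no lower from compound 1 to compound 4 (the limit leaves the size open). For the compounds shown here, this is the first measured change at this position, and it shows that a non-aromatic ring with 2 hetero atoms can replace the aromatic carbon ring there without lowering the number. The size of the step cannot be read because the result for compound 4 is a limit: the limit of > 50000 nM in this assay, at which 2 of the 4 values shown sit.

From the compounds shown here alone, whether a morpholine ring or a carboxylic acid on this carbon would give a number below that limit remains open.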